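Adding a methyl to the side chain of compound 3

A few compounds are considered here, and "the series" means these few. Any claim that something is new, unique, unknown or untested is made for them only; others in the source may bear on it.

Values in a functional assay (aorta) with Rattus norvegicus as the target; a higher number here means that more compound is needed for the effect, a lower number that less compound is needed:
- compound 1 `CCC(C)NC1=NS(=O)(=O)c2cccnc2N1`: 50.9 uM
- compound 2 `CC(NC1=NS(=O)(=O)c2cccnc2N1)C(C)(C)C`: 7.5 uM
- compound 3 `O=S1(=O)N=C(NCC2CCCCC2)Nc2ncccc21`: 45.7 uM

In this assay, compound 3 gives 45.7 uM, within the scatter of compound 1. Both values are higher than that of compound 2, so compound 3 sits at the less favourable end of this small set. Compound 4 `C[C@@H](NC1=NS(=O)(=O)c2cccnc2N1)C1CCCCC1` is the next structure to be tested, and it follows from compound 3 by one change: methyl in place of hydrogen on a saturated chain carbon bound to an amine nitrogen and a saturated ring carbon. In words, this is methyl in place of hydrogen on a saturated chain carbon bound to an amine nitrogen and a saturated ring carbon.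

For the measured compounds named here, only one measured step bears on this: a 6.8-fold lower number from compound 1 to compound 2 (0.83 log units; beyond the scatter). It falls on a similar chain carbon but is a different replacement, so it is a loose guide. A modest step to a lower number is expected, probably no larger than that one. The expected change is a 3.0-fold lower number from compound 3 to compound 4 (0.48 log units; beyond the scatter). For compound 4 the estimated value is 15 uM, with an expected range from 5 uM to 45 uM.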

Compound 4, concentration for half-maximal effect: 25.2 uM
Estimate against measurement, compound 4: 1.7-fold (0.23 log units) below, within the range that was stated.
By their numbers in this assay, from the lowest: compound 2; then compounds 4, 3 and 1 (each within the scatter of the next, the first and the last beyond it).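

In this assay, methyl in place of hydrogen on a saturated chain carbon bound to an amine nitrogen and a saturated ring carbon gives a 1.8-fold lower number from compound 3 to compound 4 (0.26 log units; within the scatter), so this single addition does not separate the two compounds. For the compounds shown here, the earlier step at a similar chain carbon, a 6.8-fold lower number from compound 1 to compound 2 (0.83 log units; beyond the scatter), lies beyond the scatter, but it is a different replacement, so the two steps show only that a change at this kind of carbon need not produce a clear shift in this assay. No available evidence accounts for this result.

The compounds shown leave open how a hydroxymethyl group or a carboxylic acid on this chain carbon would read in this assay. Also open, as far as these compounds go, is the effect of the opposite configuration at this carbon, with the methyl kept and the saturated ring unchanged.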